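The source may hold more compounds than are shown below. What is called first, only, known or untested is meant among the compounds shown, and "the series" means these compounds.

Series notes. Compound 1 `CCCC(=O)OCc1ccc2oc(=O)c(C(=O)Oc3cccc(Br)c3)cc2c1` gives 50.5% in a functional assay on HT-1080 cells (Homo sapiens), read by transwell migration, with a stated time of 24 h, tested at 1 uM; a lower number here means a stronger effect, a higher number a weaker effect of the compound at the concentration tested. Compound 2 `CCCCCC(=O)OCc1ccc2oc(=O)c(C(=O)Oc3cccc(Br)c3)cc2c1` gives 59.3% in this assay, and a number 8.8 percentage points higher from compound 1 to compound 2 (within the scatter). Compound 3 `CC(C)C(=O)OCc1ccc2oc(=O)c(C(=O)Oc3cccc(Br)c3)cc2c1` gives 37.8% in this assay, the lowest of the three numbers: a number 12.7 percentage points lower from compound 1 to compound 3 (beyond the scatter), and a number 21.5 percentage points lower from compound 2 to compound 3 (beyond the scatter). Both steps to compound 3 replace an unbranched chain on the carbonyl carbon by isopropyl, and both lower the number beyond the scatter.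

Compound 4 `CC(C)(C)C(=O)OCc1ccc2oc(=O)c(C(=O)Oc3cccc(Br)c3)cc2c1` is not yet measured in this assay. It differs from compound 3 by methyl in place of hydrogen on a saturated chain carbon bound to a carbonyl carbon and two saturated chain carbons, that is isopropyl to tert-butyl. Among the measured compounds shown here, no measured step carries the same change; the nearest evidence is that compound 3, with the branched group, sits lower than compound 1 and compound 2. On that basis a further small lowering, or none beyond the scatter, is expected: the step of a number 5.8 percentage points lower from compound 3 to compound 4 (within the scatter) is the estimate. Compound 4 is therefore expected to give 32% in this assay, in a range from 18% to 48%.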

Compound 4, a percentage reported as activity, at one concentration (the size of the read-out at that concentration, not a potency): 48.2%
For compound 4 the middle estimate is 16.2 percentage points below the measured one, and the stated range ends below it.
By their numbers in this assay, from the lowest: compound 3; then compounds 4, 1 and 2 (each within the scatter of the next, the first and the last beyond it).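

Branching on the carbonyl carbon does not act in one direction: in this assay, going from isopropyl to tert-butyl gives a number 10.4 percentage points higher from compound 3 to compound 4 (beyond the scatter) and so reverses the lowering seen with isopropyl. Among the compounds shown here, the tert-butyl group still stands apart from the longest chain (a number 11.1 percentage points lower from compound 2 to compound 4 (beyond the scatter)) but not from propyl (a number 2.3 percentage points lower from compound 1 to compound 4 (within the scatter)), which leaves compound 3 as the only member of the four with steps beyond the scatter to all the others. No measurement shown here bears on the reason for this turn.

Open, as far as these compounds go, is how a cyclopropyl group, a phenyl ring or a chain ending in an amine would read on the same carbonyl carbon. Also open, from the compounds shown here alone, is whether a methyl group there would fit the same picture.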